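Trimming a Tert-Butyl Ester: From Compound 2 to Compound 3

This account rests on a few compounds, and the source may have more. Where it says the series, first, only, none or still open, it means among the compounds named here.

Of the compounds shown here, two sharing one core have been tested in a functional assay on the whole organism (strain Swiss albino) for inhibition, with Mus musculus as the target, read by paw edema, with stated times of 30 min and 180 min, at a dose of 100 mg/kg by the subcutaneous route (on this read-out higher numbers stand for more inhibition at the one dose given (going by the name of the read-out) and lower numbers for less inhibition), so far. Compound 1 `Cc1ccc(-c2cc(C(=O)NCc3cccnc3)n(Cc3ccccc3)n2)cc1` gives 16.5% in this assay. Compound 2 `Cc1ccc(-c2cc(C(=O)Oc3ccc(C(C)(C)C)cc3)n(Cc3ccccc3)n2)cc1` gives 35% in this assay, the higher of the two numbers, and its gap to compound 1 lies beyond the usual scatter. Compound 3 `Cc1ccc(-c2cc(C(=O)Oc3ccc(C(C)C)cc3)n(Cc3ccccc3)n2)cc1` has not yet been measured; it differs from compound 2 in one place hydrogen in place of methyl on a saturated chain carbon bound to an aromatic carbon and two saturated chain carbons and cut one bond further out the change reads tert-butyl to isopropyl. Among the measured compounds shown here, no measured pair shows such a change, so the expected step of a number 4 percentage points lower from compound 2 to compound 3 (within the scatter) is small and within the scatter. Compound 3 is expected to give 31% with a range from 18% to 44% in this assay.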

Compound 3, a percentage reported as inhibition, in the whole organism at one dose (the size of the read-out at that dose, not a potency): 24%
Beside the measured number, compound 3's estimate is 7 percentage points above it; measured number inside the range.
By their numbers in this assay, from the lowest: compounds 1 and 3 (each within the scatter of the next); then compound 2.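

In this assay the loss of a single methyl from the tert-butyl group is a real step (a number 11 percentage points lower from compound 2 to compound 3 (beyond the scatter)), so this position responds to a one-carbon trim. With 4-isopropylphenoxy in place of ((pyridin-3-yl)methyl)amino on the carbonyl carbon, the step (a number 7.5 percentage points higher from compound 1 to compound 3 (within the scatter)) no longer separates the two compounds, so the edge that compound 2 held over compound 1 does not survive the trim. Nothing measured here explains the drop. Still open, as far as these compounds go, is how an ethyl group or a bare hydrogen would read in place of tert-butyl, and whether a longer chain or a carboxylic acid there would read differently again.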